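From bromine to naphthalene on a shared core

This account rests on a few compounds, and the source may have more. Where it says the series, first, only, none or still open, it means among the compounds named here.

Of the compounds shown here, two built on a shared core have been measured so far. Compound 1 `Brc1cn2ccnc2c(-c2ccc3ncn(C4CCCCC4)c3c2)n1` carries a bromine on the core; in a functional assay on SR cells (Homo sapiens) for inhibition, read by sulforhodamine B assay, with a stated time of 48 h, tested at 10 uM (a higher number here means more inhibition at the concentration tested (going by the name of the read-out), a lower number less inhibition), compound 1 gives 26.8%, the lower of the two numbers seen. Compound 2 `c1ccc(-c2cn3ccnc3c(-c3ccc4ncn(C5CCCCC5)c4c3)n2)cc1` has a phenyl ring in that place, and in this assay compound 2 gives 59.8%. The step of a number 33 percentage points higher from compound 1 to compound 2 (beyond the scatter) is the only one measured. Compound 3 `c1ccc2c(-c3cn4ccnc4c(-c4ccc5ncn(C6CCCCC6)c5c4)n3)cccc2c1` has not yet been tested. It differs from compound 1 in one place: naphthalen-1-yl in place of bromo on an aromatic carbon. A single bromine atom without a ring leaves, and a naphthalen-1-yl group made of two six-membered aromatic rings of carbon only enters on the same aromatic carbon. The bromo-to-phenyl step is the one that bears on this change, and it was large and well beyond the scatter. As naphthalen-1-yl is, like phenyl, an aromatic carbon ring in that position, a rise of similar size is expected, a number 33.2 percentage points higher from compound 1 to compound 3 (beyond the scatter). Compound 3 is therefore estimated at 60%, with a range from 35% to 85%.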

Compound 3, a percentage reported as inhibition, at one concentration (the size of the read-out at that concentration, not a potency): 6.92%
Beside the measured number, compound 3's estimate is 53.1 percentage points above it; measured number outside the range, below it.
By their numbers in this assay, from the lowest: compound 3; then compound 1; then compound 2.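

In this assay, the move to naphthalen-1-yl gives a number 19.9 percentage points lower from compound 1 to compound 3 (beyond the scatter) and, set against phenyl, it gives a number 52.9 percentage points lower from compound 2 to compound 3 (beyond the scatter), so the gain seen with phenyl does not extend to every aromatic carbon ring at this position. Among these three compounds the numbers do not climb steadily as the group grows from bromine through phenyl to naphthalen-1-yl: compound 2 stands highest, while compound 3, with the largest group, falls under even compound 1. Nothing available gives a reason for this fall.

The compounds shown leave open whether a phenyl ring carrying a methyl or methoxy group, or a naphthalen-2-yl group, would stay close to compound 2 or drop towards compound 3. As far as these compounds go, how a pyridine ring or an amine would behave at this position also remains open.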